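The compounds below may be only part of what the source reports. "The series", "measured", "known", "first", "only" and "open" are said of these compounds alone.

- Compound 1 `COc1cccc(/C=C2\CCC/C(=C\c3ccc(OC)c(OC)c3)C2=O)c1`: 3700 nM
- Compound 2 `COc1ccc(/C=C2\CCC/C(=C\c3cccc(O)c3)C2=O)cc1OC`: 1900 nM
- Compound 3 `COc1ccc(/C=C2\CCC/C(=C\c3cccc(Cl)c3Cl)C2=O)cc1OC`: 10800 nM

All three values come from a functional assay on SW-620 cells (Homo sapiens) for cytotoxicity, read by MTT assay, with a stated time of 72 h; a higher number here means a weaker inhibitor, a lower number a stronger inhibitor. Compound 3 has the highest number of the set, and both steps leading to it lie beyond the scatter: a 2.9-fold higher number from compound 1 to compound 3 (0.47 log units; beyond the scatter) and a 5.7-fold higher number from compound 2 to compound 3 (0.75 log units; beyond the scatter). The remaining step, a 1.9-fold lower number from compound 1 to compound 2 (0.29 log units; within the scatter), lies within the scatter.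

Compound 4 `COc1ccc(/C=C2\CCC/C(=C\c3ccc(O)c(O)c3)C2=O)cc1OC` has not yet been measured. It differs from compound 3 as follows: 3,4-dihydroxyphenyl in place of 2,3-dichlorophenyl on a double-bonded chain carbon bound to a double-bonded ring carbon. In words, this places 3,4-dihydroxyphenyl in place of 2,3-dichlorophenyl on a double-bonded chain carbon bound to a double-bonded ring carbon.

The two steps into compound 3 bear most directly on this change, since each exchanges an oxygen-bearing phenyl group for 2,3-dichlorophenyl. Read in reverse, both point to a lower number, of modest size. Neither partner carries 3,4-dihydroxyphenyl, however, so the comparison is only approximate. The closest guide is compound 2, with a hydroxyl-bearing ring and 1900 nM. A modest step in this assay towards a lower number is therefore expected, and the estimate is a 7.2-fold lower number from compound 3 to compound 4 (0.86 log units; beyond the scatter). For compound 4 the estimated value is 1500 nM, with an expected range from 500 nM to 4500 nM.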

Compound 4, half-maximal inhibitory concentration: 10500 nM
The estimate for compound 4 lay 7.0-fold (0.85 log units) below the measured number, outside the stated range (above it).
By their numbers in this assay, from the lowest: compounds 2 and 1 (each within the scatter of the next); then compounds 4 and 3 (each within the scatter of the next).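

Measured in this assay the exchange of 2,3-dichlorophenyl for 3,4-dihydroxyphenyl on a double-bonded chain carbon bound to a double-bonded ring carbon gives no readable difference (a 1.0-fold lower number from compound 3 to compound 4 (0.01 log units; within the scatter)), even though the entering group has 2 hydrogen-bond donors and 2 hydrogen-bond acceptors and the leaving group has none. A hydroxyl-bearing ring at this place therefore does not by itself go with a low number: the added hydroxy takes the series up from the 3-hydroxyphenyl of compound 2 (a 5.5-fold higher number from compound 2 to compound 4 (0.74 log units; beyond the scatter)), and the 3,4-dihydroxyphenyl group also stands higher than the 3-methoxyphenyl group (a 2.8-fold higher number from compound 1 to compound 4 (0.45 log units; beyond the scatter)), so compound 2 is now the one oxygen-bearing case that goes against the high numbers of compound 3 and compound 4. No measurement offered here explains why the second hydroxy has this effect.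

The compounds shown leave open whether this rise belongs to the pair of hydroxy groups or to the added hydroxy alone, which 4-hydroxyphenyl at this place would help to separate. They also leave open how an amine or a carboxylic acid on this phenyl ring would compare with the hydroxy and chlorine groups.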